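From a cyclobutyl to a phenyl on the chain carbon

This account rests on a few compounds, and the source may have more. Where it says the series, first, only, none or still open, it means among the compounds named here.

Two measured compounds share one core and differ only in the group on the saturated chain carbon bound to an aromatic nitrogen. Compound 1, `CC(C)(F)CCn1nc(-c2cccs2)c(O)c(C2=NS(=O)(=O)c3cc(OCC(N)=O)ccc3N2)c1=O`, carries a 2-fluoro-2-methylpropyl group there, and in an in vitro ADME assay on microsomes from liver (Homo sapiens) for metabolic stability (on this read-out higher numbers stand for a longer-lived compound and lower numbers for a shorter-lived compound), compound 1 gives 0.65 h. Compound 2, `NC(=O)COc1ccc2c(c1)S(=O)(=O)N=C(c1c(O)c(-c3cccs3)nn(CC3CCC3)c1=O)N2`, carries a cyclobutyl at that place, and in this assay compound 2 gives 0.367 h. Within the data shown here, the single step between them, a 1.8-fold lower number from compound 1 to compound 2 (0.25 log units; within the scatter), means the two numbers cannot be told apart, so compound 2 stands beside compound 1 rather than apart from it.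

Compound 3, `NC(=O)COc1ccc2c(c1)S(=O)(=O)N=C(c1c(O)c(-c3cccs3)nn(Cc3ccccc3)c1=O)N2`, differs from compound 2 by phenyl in place of cyclobutyl on a saturated chain carbon bound to an aromatic nitrogen. Among the measured compounds shown here, the one measured step touches the same place, but it exchanged one saturated group for another and did not move the half-life beyond the scatter; no measured step brings an aromatic ring to this place. These numbers therefore give no basis for expecting a step beyond the scatter. Compound 3 is expected to give 0.35 h in this assay, within a range from 0.15 h to 0.8 h. The expected step is a 1.0-fold lower number from compound 2 to compound 3 (0.02 log units; within the scatter), an estimate only.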

Compound 3, half-life: 0.383 h
Beside the measured number, compound 3's estimate is 1.1-fold (0.04 log units) below it; low and high end bracket the measured number.
By their numbers in this assay, from the lowest: compounds 2, 3 and 1 (each within the scatter of the next).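

In this assay, an aromatic ring now stands at this place, and the result is a 1.0-fold higher number from compound 2 to compound 3 (0.02 log units; within the scatter), so phenyl and cyclobutyl cannot be told apart here. Set against the open chain of compound 1, the outcome is the same, with a 1.7-fold lower number from compound 1 to compound 3 (0.23 log units; within the scatter). Across these three compounds, then, an open fluorinated chain, a saturated ring and an aromatic ring on a saturated chain carbon bound to an aromatic nitrogen all give half-lives that lie within the scatter of one another, and nothing available explains this sameness.

On these data alone, what stays open is whether any group at this place can move the half-life beyond the scatter, for instance an amine, a carboxylic acid or a pyridine ring in place of the phenyl. As far as these compounds go, these three compounds also say nothing about changes elsewhere on the shared core, which is identical in all of them, so the part of the molecule that governs the half-life in this test remains unknown.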